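Methyl on a Phenol Oxygen: Expected Effect on Cell Growth

The source may report more compounds than this note shows. Statements on the series, on what has been measured and on what is new or still open speak of the compounds shown alone.

Of the compounds shown here, three built on one shared core have been tested in a functional assay on CCRF-CEM cells (Homo sapiens) for inhibition, read by sulforhodamine B assay, with a stated time of 48 h, tested at 0.01 uM; a higher number here means a weaker effect of the compound at the concentration tested, a lower number a stronger effect. Compound 1 `O=C(Nc1cccc(-n2cc(-c3ccncc3)c(-c3cc(O)cc(Cl)c3)n2)c1)Nc1ccc(Cl)c(C(F)(F)F)c1` gives 97%. Compound 2 `O=C(Nc1cccc(-n2cc(-c3ccncc3)c(-c3cc(O)cc(Cl)c3)n2)c1)Nc1ccc(Cl)c(Cl)c1` gives 96%, and the step of a number 1 percentage points lower from compound 1 to compound 2 (within the scatter) lies within the scatter. Compound 3 `COc1cc(Cl)cc(-c2nn(-c3cccc(NC(=O)Nc4cc(C(F)(F)F)cc(C(F)(F)F)c4)c3)cc2-c2ccncc2)c1` gives 87%; it differs from compound 1 in more than one place, so only its number can be compared. Compound 2 thus sits between compound 1 and compound 3, and all three numbers lie within the scatter of one another.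

Compound 4 `COc1cc(Cl)cc(-c2nn(-c3cccc(NC(=O)Nc4ccc(Cl)c(Cl)c4)c3)cc2-c2ccncc2)c1` differs from compound 2 by methyl in place of hydrogen on an oxygen on an aromatic ring. Within the data shown here, no measured step changes only this oxygen. Among the measured compounds shown here, the one hint is compound 3, which carries the methoxy and whose number stays within the scatter of compound 2, though compound 3 also differs elsewhere. The step from compound 2 to compound 4 is therefore expected to be small, a number 4 percentage points lower from compound 2 to compound 4 (within the scatter), with no clear direction. Compound 4 is estimated at 92%, with a range from 80% to 100%.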

Compound 4, a percentage reported as activity, at one concentration (the size of the read-out at that concentration, not a potency): 97%
Beside the measured number, compound 4's estimate is 5 percentage points below it; the range from low to high includes it.
By their numbers in this assay, from the lowest: compounds 3, 2, 1 and 4 (each within the scatter of the next).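

Among these compounds, compound 4 gives the first clean reading of this oxygen: in this assay, methyl in place of hydrogen gives a number 1 percentage points higher from compound 2 to compound 4 (within the scatter), with the rest of the structure unchanged. Compound 3 could only hint at this, since it also differs elsewhere, whereas this pair isolates hydroxy to methoxy and shows that, at this one concentration, the read-out does not separate the 3-chloro-5-hydroxyphenyl from the 3-chloro-5-methoxyphenyl compound. No measurement at hand offers an explanation for this result.

The compounds shown leave open whether a longer chain on this oxygen, such as ethoxy, or an amine in place of the hydroxy, would also stay within the scatter. They also cannot tell whether hydroxy and methoxy would part at a higher concentration, where a fuller effect might be seen.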